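The source may report more compounds than this note shows. Statements on the series, on what has been measured and on what is new or still open speak of the compounds shown alone.

In a physicochemical assay for solubility, using the shake flask method, measured as kinetic solubility, with a stated time of 20 h, at pH 2 (on this read-out higher numbers stand for higher solubility and lower numbers for lower solubility), compound 1 `FC(F)(F)c1cccc(-c2nc3cnc(Nc4ccccn4)cc3[nH]2)c1` gives 21000 nM. Compound 2 `Fc1ccc(-c2nc3cnc(Nc4ccccn4)cc3[nH]2)cc1F` has a core whose difference from that of compound 1 is not broken down here; in this assay compound 2 gives 125000 nM, the higher of the two numbers. Compound 3 `FC(F)(F)c1ccc(Nc2cc3[nH]c(-c4cccc(C(F)(F)F)c4)nc3cn2)nc1` carries trifluoromethyl in place of hydrogen on an aromatic carbon. In this assay compound 3 gives only a limit, < 5000 nM. The step of an at least 4.2-fold lower number from compound 1 to compound 3 (0.62 log units; beyond the scatter) is therefore bounded by the limit of < 5000 nM in this assay, at which 1 of the 3 values shown sits. Compound 4 `Fc1ccc(-c2nc3cnc(Nc4cc(C(F)(F)F)ccn4)cc3[nH]2)cc1F` carries the same kind of change on the core of compound 2, (trifluoromethyl in place of hydrogen on an aromatic carbon), although here the group sits meta to a large group and opposite the ring nitrogen, whereas in compound 3 it sits two atoms from the ring nitrogen and para to a large group. Because the earlier step of an at least 4.2-fold lower number from compound 1 to compound 3 (0.62 log units; beyond the scatter) lowered the number, a step of about a 5.0-fold lower number from compound 2 to compound 4 (0.70 log units; beyond the scatter) is expected this time as well. Compound 4 is thus estimated to give 25000 nM, somewhere between 8000 nM and 70000 nM.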

Compound 4, solubility: < 5000 nM
Compound 4 ended at the assay's limit; the forecaster's own chance of this, stated with the estimate: 10%; at least 5.0-fold (0.69 log units) between middle value and limit.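

In this assay, trifluoromethyl in place of hydrogen on an aromatic carbon lowers the number on the core of compound 2, with an at least 25-fold lower number from compound 2 to compound 4 (1.39 log units; beyond the scatter), and the change points the same way on the core of compound 1, with an at least 4.2-fold lower number from compound 1 to compound 3 (0.62 log units; beyond the scatter). Compound 4 gives < 5000 nM, which is a limit and not a number, so the two steps cannot be compared in size: the limit of < 5000 nM in this assay, at which 2 of the 4 values shown sit. These two pairs show that the direction carried over from one core to the other, although the group sits at a different place in each, but they do not show how much of either step belongs to the core or to that place. The compounds shown leave open what an amine or a carboxylic acid at the same place would give on either core.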